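A few compounds are considered here, and "the series" means these few. Any claim that something is new, unique, unknown or untested is made for them only; others in the source may bear on it.

Working notes on the series.

Compound 1 `CCCc1ccc(NC(=O)N[C@H](C)c2ccccc2)cc1` carries a propyl group on the aromatic carbon of the shared core. In an ADME assay on the whole organism with Oryza sativa as the target, tested at 10 uM (a lower number here means a stronger effect, a higher number a weaker effect of the compound at the concentration tested), compound 1 gives 35%. Compound 2 `C[C@@H](NC(=O)Nc1ccc(C(F)(F)F)cc1)c1ccccc1` carries trifluoromethyl in that position; in this assay compound 2 gives 82%, and the step is a number 47 percentage points higher from compound 1 to compound 2 (beyond the scatter). Compound 3 `CCOC(=O)c1ccc(NC(=O)N[C@H](C)c2ccccc2)cc1` carries ethoxycarbonyl there; in this assay compound 3 gives 92%, which is the highest of the three numbers. The step is a number 57 percentage points higher from compound 1 to compound 3 (beyond the scatter), while compound 2 and compound 3 lie close to one another: a number 10 percentage points higher from compound 2 to compound 3 (within the scatter).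

Compound 4 `C[C@@H](NC(=O)Nc1ccc(Br)cc1)c1ccccc1` is the next member. The difference from compound 3 is bromo in place of ethoxycarbonyl on an aromatic carbon.

Which measured steps bear on this: the two large steps from compound 1, a number 47 percentage points higher from compound 1 to compound 2 (beyond the scatter) and a number 57 percentage points higher from compound 1 to compound 3 (beyond the scatter), show that two quite different substituents in this position both sit far above the propyl compound, and the step of a number 10 percentage points higher from compound 2 to compound 3 (within the scatter) shows that the choice between them made no difference beyond the scatter. Bromo is a third, smaller substituent in the same place; no measured step covers it directly. On that basis compound 4 is expected to stay near the upper pair rather than fall back toward compound 1, though with a wide range: the estimated step is a number 17 percentage points lower from compound 3 to compound 4 (beyond the scatter), and in this assay compound 4 is estimated at 75%, between 45% and 95%.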

Compound 4, a percentage reported as activity, at one concentration (the size of the read-out at that concentration, not a potency): 87%
For compound 4 the middle estimate is 12 percentage points below the measured one, and the stated range covers the measured number.
By their numbers in this assay, from the lowest: compound 1; then compounds 2, 4 and 3 (each within the scatter of the next).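

Replacing ethoxycarbonyl (5 heavy atoms, 2 hydrogen-bond acceptors) with bromo (1 heavy atom, 0 hydrogen-bond acceptors) gives a number 5 percentage points lower from compound 3 to compound 4 (within the scatter) in this assay and so does not separate the two groups, while the comparison with trifluoromethyl gives a number 5 percentage points higher from compound 2 to compound 4 (within the scatter) and likewise separates nothing. Among the compounds shown here, on an aromatic carbon para to a large group, compounds 2, 3 and 4 therefore form one group in this read-out despite the difference in heavy atoms and acceptors between ethoxycarbonyl and bromo, and a number 52 percentage points higher from compound 1 to compound 4 (beyond the scatter) adds a third substituent that stands clearly apart from propyl, leaving compound 1 as the only member outside that group. Nothing measured on these compounds offers an explanation for either the close grouping or the separate position of compound 1.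

Going by these compounds, it remains open whether the low number of compound 1 belongs to propyl alone or extends to alkyl groups more widely, which methyl, ethyl or a longer chain such as butyl at this place would help settle. Also open, on these data alone, is where a hydrogen, an amine or a carboxylic acid at this place would fall relative to compounds 1 to 4.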